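A few compounds are considered here, and "the series" means these few. Any claim that something is new, unique, unknown or untested is made for them only; others in the source may bear on it.

In an ADME assay on 184B5 cells (Homo sapiens) for cytotoxicity, read by MTT assay, with a stated time of 72 h (on this read-out lower numbers stand for stronger inhibition of growth and higher numbers for weaker inhibition of growth), the measured compounds are:
compound 1 `CCCCC[Se]c1nc(NCc2ccccc2)c2ccccc2n1` with 70900 nM;
compound 2 `CSc1ccc(CNc2nc([SeH])nc3ccccc23)cc1` with 6840 nM;
compound 3 `CCCCC[Se]c1nc(NCc2ccc(SC)cc2)c2ccccc2n1` with 57400 nM.

Compound 3 holds the second highest of these three numbers. Its nearest neighbour is compound 1, separated by a 1.2-fold lower number from compound 1 to compound 3 (0.09 log units; within the scatter), which is within the scatter. Its furthest is compound 2, separated by an 8.4-fold higher number from compound 2 to compound 3 (0.92 log units; beyond the scatter), which is beyond the scatter.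

Compound 4 `CSc1ccc(CNc2nc(SC)nc3ccccc23)cc1` differs from compound 3 by a group of 2 heavy atoms (1 carbon, 1 sulfur; no ring) in place of a group of 6 heavy atoms (5 carbon, 1 selenium; no ring), on an aromatic carbon. Among the compounds with values here, only one measured step touches that position, the one on the selenium, an 8.4-fold higher number from compound 2 to compound 3 (0.92 log units; beyond the scatter), where the longer chain went with a higher number. Compound 4 carries a short group there rather than the bare selenium of compound 2, so a lower number than compound 3 is expected, smaller than that step. Compound 4 is estimated at 20000 nM, in the range 6000 nM to 60000 nM, a step of a 2.9-fold lower number from compound 3 to compound 4 (0.46 log units; beyond the scatter).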

Compound 4, concentration for 50% growth inhibition: 22000 nM
Compound 4: middle estimate off by 1.1-fold (0.04 log units), on the low side; the range from low to high includes it.
By their numbers in this assay, from the lowest: compound 2; then compound 4; then compounds 3 and 1 (each within the scatter of the next).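

On the aromatic carbon between two ring nitrogen atoms, methylsulfanyl in place of the group of 6 heavy atoms goes with a 2.6-fold lower number from compound 3 to compound 4 (0.42 log units; beyond the scatter), a first sign that the selenium chain can be shortened and exchanged without reaching the lowest number. The bare selenium of compound 2 still stands lower, with a 3.2-fold higher number from compound 2 to compound 4 (0.51 log units; beyond the scatter), so across these three compounds the number rises with the size of the group. Sulfur and chain length change together in compound 4, so their shares cannot be separated, and no evidence is given for a cause of these steps.

From the compounds shown here alone, it remains open how an amine, or a pentyl chain on sulfur, would read at this position.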